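Swapping the nitro of compound 1 for trifluoromethyl

The source may report more compounds than this note shows. Statements on the series, on what has been measured and on what is new or still open speak of the compounds shown alone.

Compound 1, with the structure `O=[N+]([O-])c1ccc(S(=O)(=O)NCCCCCCNCc2ccc(Br)cc2)cc1`, was tested in a functional assay on MIA PaCa-2 cells (Homo sapiens) for inhibition, read by MTT assay, with a stated time of 72 h; a lower number here means a stronger inhibitor of growth, a higher number a weaker inhibitor of growth. In this assay compound 1 gives 9800 nM, the highest of the two numbers in hand; its nearest neighbour is compound 2, drawn as `O=S(=O)(NCCCNCc1ccc(Cl)c(C(F)(F)F)c1)c1cc(C(F)(F)F)cc(C(F)(F)F)c1`, which in this assay gives 7400 nM, a gap that lies within the scatter of the measurement. Compound 3, with the structure `O=S(=O)(NCCCCCCNCc1ccc(Br)cc1)c1ccc(C(F)(F)F)cc1`, has not yet been measured in this assay. It differs from compound 1 by trifluoromethyl in place of nitro on an aromatic carbon, on an aromatic carbon of a six-membered aromatic ring of carbon only, para to a large group. No step between measured compounds exists for this exchange, so the direction of the change cannot be read from the numbers shown. For compound 3 in this assay a value of 7000 nM is expected, with a range from 2500 nM to 20000 nM. This expectation means a step from compound 1 to compound 3 of a 1.4-fold lower number from compound 1 to compound 3 (0.15 log units; within the scatter), not beyond the scatter.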

Compound 3, concentration for 50% growth inhibition: 3830 nM
The estimate for compound 3 lay 1.8-fold (0.26 log units) above the measured number; low and high end bracket the measured number.
By their numbers in this assay, from the lowest: compounds 3, 2 and 1 (each within the scatter of the next, the first and the last beyond it).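

In this assay, among these compounds, the exchange of nitro for trifluoromethyl, on an aromatic carbon para to a large group, gives a 2.6-fold lower number from compound 1 to compound 3 (0.41 log units; beyond the scatter) and is the first step between measured compounds that differ in one place. The step is modest but lies beyond the scatter, so the group at this position does affect the read-out, and nitro is not required there for growth inhibition in these cells. No evidence on the origin of this step is at hand.

On these data alone, it remains open whether other groups at this position, such as a nitrile, a methoxy group, an amine or a carboxylic acid, would give a lower or a higher number than trifluoromethyl. Also open, as far as these compounds go, is whether the step would hold with a shorter or longer chain, since compound 2 differs from compound 3 in more than one place and cannot answer this.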